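The compounds below may be only part of what the source reports. "The series", "measured", "known", "first", "only" and "open" are said of these compounds alone.

In an ADME assay on L929 cells (Mus musculus) for cytotoxicity, read by resazurin assay, with a stated time of 96 h (a higher number here means that more compound is tolerated, a lower number that less compound is tolerated), compound 1 `CCc1ccc(OC/C(=N\NC(N)=S)c2ccc(Br)cc2)cc1` gives < 25500 nM as its entry, and that entry is a limit, not a number. Compound 2 `CC(C)c1ccc(OC/C(=N\NC(N)=S)c2ccc(Br)cc2)cc1` gives 24600 nM and compound 3 `CC(C)(C)c1ccc(OC/C(=N\NC(N)=S)c2ccc(Br)cc2)cc1` gives 23800 nM as measured numbers, with a 1.0-fold lower number from compound 2 to compound 3 (0.01 log units; within the scatter) as the step, so compound 3 stands level with compound 2. The other step into compound 3, a step that the limit leaves unreadable from compound 1 to compound 3, offers nothing to read.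

Compound 4 `COc1ccc(OC/C(=N\NC(N)=S)c2ccc(Br)cc2)cc1` has methoxy in place of tert-butyl on an aromatic carbon, para to a large group, with methoxy in place of tert-butyl on an aromatic carbon as the counted difference. Methoxy has not yet been measured at this place. Within the data shown here, with a 1.0-fold lower number from compound 2 to compound 3 (0.01 log units; within the scatter) as the only readable guide to a change of this group, no step beyond the scatter is expected, and the direction stays open. In this assay the expected change is a 1.1-fold higher number from compound 3 to compound 4 (0.04 log units; within the scatter) and no more than the scatter. For compound 4 the estimated value is 26000 nM with an expected range from 13000 nM to 52000 nM as the working figure.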

Compound 4, half-maximal cytotoxic concentration: 102000 nM
Compound 4: the middle estimate sits 3.9-fold (0.59 log units) below what was measured; measured number above the stated range.
By their numbers in this assay, from the lowest: compounds 3 and 2 (each within the scatter of the next); then compound 4.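

In this assay, the group on this aromatic carbon now makes a difference: the change between isopropyl and tert-butyl stayed within the scatter, whereas methoxy in place of tert-butyl gives a 4.3-fold higher number from compound 3 to compound 4 (0.63 log units; beyond the scatter), and methoxy in place of isopropyl gives a 4.1-fold higher number from compound 2 to compound 4 (0.62 log units; beyond the scatter). Methoxy in place of ethyl gives an at least 4.0-fold higher number from compound 1 to compound 4 (0.60 log units; beyond the scatter), so compound 4 stands apart from all three compounds with a carbon-only group here. The entry of compound 1 is a limit, so that last step has no exact size: the limit of < 25500 nM in this assay, at which 1 of the 4 values shown sits.

Methoxy differs from tert-butyl both in heavy atoms and in hydrogen-bond acceptors, and the compounds shown do not separate the two differences. Ethoxy, hydroxyl or an amine on this aromatic carbon would help to separate them.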